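The source may report more compounds than this note shows. Statements on the series, on what has been measured and on what is new or still open speak of the compounds shown alone.

Values in a functional assay on PC-3 cells (Homo sapiens) for inhibition, read by sulforhodamine B assay, with a stated time of 72 h (on this read-out higher numbers stand for weaker inhibition and lower numbers for stronger inhibition), for the series so far
compound 1 (`Nc1sc(-c2ccc(Cl)cc2)c(-c2ccc(Cl)cc2)c1C(=O)NC1CCC1`) 24800 nM
compound 2 (`Nc1sc(-c2ccc(Cl)cc2)c(-c2ccc(Cl)cc2)c1C(=O)NC1CCC(O)CC1`) 5670 nM
compound 3 (`Nc1sc(-c2ccc(Cl)cc2)c(-c2ccc(Cl)cc2)c1C(=O)N1CCCC1`) 6220 nM

Compound 3 and compound 2 lie within the scatter of each other (a 1.1-fold higher number from compound 2 to compound 3 (0.04 log units; within the scatter)), and compound 1 gives the highest number of the three. Compound 4 (`Nc1sc(-c2ccc(Cl)cc2)c(-c2ccc(Cl)cc2)c1C(=O)NC1CC1`) has cyclopropylamino in place of pyrrolidin-1-yl on a carbonyl carbon. Its nearest measured neighbour is compound 1, with cyclobutyl on an amide-type nitrogen. The step bearing most directly is therefore the modest one (a 4.0-fold lower number from compound 1 to compound 3 (0.60 log units; beyond the scatter)), read here in reverse. Compound 2 goes against a simple link between the amide hydrogen and a higher number: it keeps that hydrogen, yet its number is lower (a 4.4-fold lower number from compound 1 to compound 2 (0.64 log units; beyond the scatter)). No cyclopropyl amide has been measured, so the direction remains tentative. A modest rise in the number is expected in this assay (a 2.9-fold higher number from compound 3 to compound 4 (0.46 log units; beyond the scatter)). For compound 4 the estimated value is 18000 nM with an expected range from 7000 nM to 45000 nM at this stage.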

Compound 4, half-maximal inhibitory concentration: 3680 nM
Beside the measured number, compound 4's estimate is 4.9-fold (0.69 log units) above it; the measured number lies below the stated range.
By their numbers in this assay, from the lowest: compounds 4, 2 and 3 (each within the scatter of the next); then compound 1.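

In this assay, cyclopropylamino on the carbonyl carbon keeps the amide hydrogen, yet compound 4 cannot be told apart from the pyrrolidin-1-yl amide (a 1.7-fold lower number from compound 3 to compound 4 (0.23 log units; within the scatter)) or from the 4-hydroxycyclohexyl amide (a 1.5-fold lower number from compound 2 to compound 4 (0.19 log units; within the scatter)). Among these compounds, the clear change lies in the ring on the amide-type nitrogen, where cyclopropyl replaces cyclobutyl (a 6.7-fold lower number from compound 1 to compound 4 (0.83 log units; beyond the scatter)), leaving compound 1 as the only compound set apart from the other three. No measurement here accounts for these differences.

Going by these compounds, whether the high number of compound 1 is confined to cyclobutyl remains open: the amide-type nitrogen carries only cyclopropyl, cyclobutyl and 4-hydroxycyclohexyl. Also open, on these data alone, is how a cyclopentyl, an unsubstituted cyclohexyl, an open-chain isopropyl or a 4-aminocyclohexyl amide would read.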